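The compounds below may be only part of what the source reports. "The series", "measured", "known", "first", "only" and "open" are said of these compounds alone.

Going by the values given here, in a functional assay on A549 cells (Homo sapiens) for antiproliferative activity, read by sulforhodamine B assay, with a stated time of 72 h (a higher number here means a weaker inhibitor, a lower number a stronger inhibitor), compound 1 (`CC(=O)Nc1ccc(S(=O)(=O)Nc2cc(SCC(=O)N[C@@H](CC(C)C)B(O)O)c(O)c3ccccc23)cc1`) gives 6700 nM, the only number available for it; one further entry carries no single number. With so little data, its standing in the series rests on a single comparison: compound 2 (`CC(C)C[C@H](NC(=O)C(C)Sc1cc(NS(=O)(=O)c2ccc(Cl)cc2)c2ccccc2c1O)B(O)O`) gives 12800 nM; 16500 nM (2 entries) over its two entries. Compound 3 (`CC(=O)Nc1ccc(S(=O)(=O)Nc2cc(SC(C)C(=O)N[C@@H](CC(C)C)B(O)O)c(O)c3ccccc23)cc1`) differs from compound 1 by methyl in place of hydrogen on a saturated chain carbon bound to a carbonyl carbon and a sulfur. Among the compounds with values here, no measured step in this assay isolates this change, so the expectation is loose, and the value of compound 2 at 12800 nM; 16500 nM (2 entries) is the only guide to how far it might reach. A small move toward weaker inhibition is expected, a 1.3-fold higher number from compound 1 to compound 3 (0.13 log units; within the scatter), and it may well stay within the scatter. For compound 3 the estimate is 9000 nM, with an expected range of 3500 nM to 22000 nM.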

Compound 3, half-maximal inhibitory concentration: 6370 nM
The estimate for compound 3 lay 1.4-fold (0.15 log units) above the measured number, within the range that was stated.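

In this assay, methyl in place of hydrogen on a saturated chain carbon bound to a carbonyl carbon and a sulfur gives a 1.1-fold lower number from compound 1 to compound 3 (0.02 log units; within the scatter), so this place accepts the added methyl with no readable change in antiproliferative activity. Going by these compounds alone, the earlier compounds offered no step at all, and this pair is the first direct reading of this change. The step is also smaller than the spread between repeat entries of a single compound: the several entries of compound 2 in this assay, 12800 nM; 16500 nM (2 entries)

One methyl says little about how much more this place would tolerate. From the compounds shown here alone, whether an ethyl group, a longer chain or a carboxylic acid on the same carbon would move the number beyond the scatter remains open.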